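Carboxy to carbamoyl: compound 2 to compound 3

The source may hold more compounds than are shown below. What is called first, only, known or untested is meant among the compounds shown, and "the series" means these compounds.

Of the compounds shown here, two so far have numbers in a functional assay on HepG2 cells (Homo sapiens) for cytotoxicity, read by sulforhodamine B assay, with a stated time of 48 h; on this read-out lower numbers stand for stronger inhibition of growth and higher numbers for weaker inhibition of growth. Compound 1 (`Cc1nn(-c2ccccc2)c(Oc2ccc(-c3nc4cc([N+](=O)[O-])ccc4[nH]3)cc2)c1/C=N/Nc1ccccc1`) gives 58500 nM. Compound 2 (`Cc1nn(-c2ccccc2)c(Oc2ccc(-c3nc4cc(C(=O)O)ccc4[nH]3)cc2)c1/C=N/NC(N)=S`) gives 46000 nM. These two values lie within the scatter of each other, so compound 2 stands level with compound 1 and neither can be ranked. The pair differs in more than one place, so no measured single change is available as a guide.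

Compound 3 (`Cc1nn(-c2ccccc2)c(Oc2ccc(-c3nc4cc(C(N)=O)ccc4[nH]3)cc2)c1/C=N/NC(N)=S`) has amino in place of hydroxy on a carbonyl carbon, which reads as carboxy to carbamoyl: amino in place of hydroxy on a carbonyl carbon. No shift beyond the scatter is expected in this assay, and no direction is favoured. This expectation rests on compound 2 at 46000 nM alone. The estimated step of a 1.1-fold lower number from compound 2 to compound 3 (0.04 log units; within the scatter) stays within the scatter. For compound 3 the estimated value is 42000 nM, with an expected range of 16000 nM to 100000 nM.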

Compound 3, concentration for 50% growth inhibition: 37500 nM
Beside the measured number, compound 3's estimate is 1.1-fold (0.05 log units) above it; measured number inside the range.
By their numbers in this assay, from the lowest: compounds 3, 2 and 1 (each within the scatter of the next).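

In this assay the series now has its first single change that can be read (a step of a 1.2-fold lower number from compound 2 to compound 3 (0.09 log units; within the scatter)), with amino in place of hydroxy on a carbonyl carbon whose other neighbour is an aromatic carbon. Carboxy and carbamoyl therefore cannot be told apart at this place on the shared core, and this one pair gives no sign that the exchange matters for growth inhibition. No measured evidence at hand explains this result.

Going by these compounds, whether a nitrile or a methyl ester at this place would give a number beyond the scatter of compound 2 remains open. Also open, on these data alone, is whether amino in place of hydroxy on this carbonyl carbon reads the same when the rest of the molecule differs, since a single pair cannot show this.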